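This account rests on a few compounds, and the source may have more. Where it says the series, first, only, none or still open, it means among the compounds named here.

Measured compounds:
compound 1, `COc1cc(C(=O)/C=C\Nc2ccc(-c3nc4cc(OC)c(OC)c(OC)c4s3)cc2)c(Br)c(OC)c1OC`: 23200 nM
compound 2, `COc1cc(OC)c2sc(-c3ccc(N/C=C\C(=O)c4ccc(OC)c(O)c4)cc3)nc2c1`: 11600 nM
compound 3, `COc1ccc2nc(-c3ccc(N/C=C\C(=O)c4ccc(OC)c([N+](=O)[O-])c4)c(C)c3)sc2c1`: 23600 nM

In a functional assay on MIA PaCa-2 cells (Homo sapiens) for antiproliferative activity, read by sulforhodamine B assay, with a stated time of 48 h (a higher number here means a weaker inhibitor, a lower number a stronger inhibitor), compound 1 gives 23200 nM, the second highest of the three numbers. Its nearest neighbour is compound 3, which gives 23600 nM, a value within the scatter of compound 1. The furthest is compound 2, which gives 11600 nM; that gap also lies within the scatter, so the three measured compounds cannot be ranked against one another, and all three are weak inhibitors in this assay.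

The new compound 4, `COc1cc(OC)c2sc(-c3ccc(N/C=C\C(=O)c4cc(OC)c(OC)c(OC)c4Br)cc3)nc2c1`, differs from compound 1 at one place: hydrogen in place of methoxy on an aromatic carbon. The methoxy that leaves sits on the fused two-ring portion of the shared core, while the aryl ketone side of the molecule is unchanged. Among the compounds with values here, no measured pair shows this exact change, so its effect must be judged from the spread of the three values, which is itself narrow. The step from compound 1 to compound 4 is expected to be small, with no direction beyond the scatter; the estimated change is a 1.3-fold lower number from compound 1 to compound 4 (0.11 log units; within the scatter). Compound 4 is therefore expected to give about 18000 nM in this assay, within a range from 6000 nM to 50000 nM.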

Compound 4, half-maximal inhibitory concentration: 19000 nM
For compound 4 the middle estimate is 1.1-fold (0.02 log units) below the measured one; measured number inside the range.
By their numbers in this assay, from the lowest: compounds 2, 4, 1 and 3 (each within the scatter of the next, the first and the last beyond it).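

In this assay, hydrogen in place of methoxy on an aromatic carbon, ortho to two methoxy groups, gives a 1.2-fold lower number from compound 1 to compound 4 (0.09 log units; within the scatter) and so stays within the scatter. Within the data shown here, this is the first direct reading of this position, since none of the earlier compounds formed a pair differing in one place, and it shows that, with the aryl ketone side of the molecule held constant, the loss of this one methoxy leaves no change that can be told from the scatter. The result is limited to this single pair and this one change, and the measurements shown offer no independent information on why the number holds as it does.

The compounds shown leave open whether any other group at this place would move the number beyond the scatter, for example a longer chain such as butoxy, an amine or a carboxylic acid. They also leave open whether the two remaining methoxy groups on this ring can be replaced by hydrogen in the same way, singly or together, and whether the outcome would hold with a different aryl ketone.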